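A few compounds are considered here, and "the series" means these few. Any claim that something is new, unique, unknown or untested is made for them only; others in the source may bear on it.

Of the compounds shown here, three have so far been read in a functional assay on DU-145 cells (Homo sapiens) for inhibition, read by CCK-8 assay, with a stated time of 72 h; on this read-out lower numbers stand for stronger inhibition and higher numbers for weaker inhibition. Compound 1 (`O=C(/C=C/c1cccnc1)NCCCCCc1ccc(S(=O)(=O)Nc2ccccc2)cc1`) gives 581 nM and compound 2 (`O=C(/C=C/c1cccnc1)NCCCCCCCc1cccc(S(=O)(=O)Nc2ccccc2)c1`) gives 429 nM, two values within the usual scatter of each other. Compound 3 (`Cc1cccc(NS(=O)(=O)c2cccc(CCCCCCNC(=O)/C=C/c3cccnc3)c2)c1`) gives 41.7 nM, the lowest of the three numbers, and its distance from each of the other two lies beyond the scatter. That makes compound 3 the most potent of the set in this assay.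

Compound 4 (`O=C(/C=C/c1cccnc1)NCCCCCCc1cccc(S(=O)(=O)Nc2ccc(C(F)(F)F)cc2)c1`) keeps the rest of compound 3 and alters only the group on the sulfonamide nitrogen, with 4-(trifluoromethyl)phenyl in place of 3-methylphenyl on a sulfonamide nitrogen. Within the data shown here, no measured pair differs in one place, so the data give no direct guide to this change. Both other measured compounds differ from compound 3 in more than one place. Among the measured compounds shown here, still, the only other numbers lie on the higher side, with compound 2 at 429 nM, so a rise looks likelier than a fall. The expected change is a 2.9-fold higher number from compound 3 to compound 4 (0.46 log units; beyond the scatter), a moderate move toward weaker inhibition that is estimated to lie somewhat beyond the scatter. For compound 4 the estimate is 120 nM, with an expected range from 30 nM to 480 nM.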

Compound 4, half-maximal inhibitory concentration: 1410 nM
Compound 4: middle estimate off by 12-fold (1.07 log units), on the low side; measured number above the stated range.
By their numbers in this assay, from the lowest: compound 3; then compounds 2 and 1 (each within the scatter of the next); then compound 4.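

The exchange of 3-methylphenyl for 4-(trifluoromethyl)phenyl on the sulfonamide nitrogen gives the series its first comparison that differs in one place, and in this assay it reads as a 34-fold higher number from compound 3 to compound 4 (1.53 log units; beyond the scatter), a large move toward weaker inhibition. It shows that the read-out is highly sensitive to the group at this nitrogen, even though the leaving and entering groups each carry one six-membered aromatic ring of carbon only, neither has a hydrogen-bond donor or acceptor, and neither has a net charge. No measurement at hand bears on why this single exchange has so large an effect.

Since the methyl and trifluoromethyl groups also sit at different places on the ring, the compounds shown leave open whether the change follows the identity of the group, its place, or both. Also open, going by these compounds, is how the same sulfonamide nitrogen would read with a methoxy group or a chlorine atom on the phenyl ring, or with a small alkyl group in place of the aromatic ring.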